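Oxime ether series: carbamate replacing isopropyl on the oxime oxygen

A few compounds are considered here, and "the series" means these few. Any claim that something is new, unique, unknown or untested is made for them only; others in the source may bear on it.

Measured so far, in a functional assay (blood) for inhibition, with Homo sapiens as the target; on this read-out higher numbers stand for weaker inhibition and lower numbers for stronger inhibition:
- compound 1, `C/C(=N\OCCSc1nnc(C)s1)c1ccc(Sc2cc(F)cc(C3CCOCC3)c2)cc1`: 230 nM
- compound 2, `CC(C)/C(=N\O)c1ccc(Sc2cc(F)cc(C3CCOCC3)c2)cc1`: 300 nM
- compound 3, `C/C(=N\OC(C)C)c1ccc(Sc2cc(F)cc(C3CCOCC3)c2)cc1`: 920 nM

Compound 3 gives the highest of the three numbers in this assay. Its nearest neighbour is compound 2, with a 3.1-fold higher number from compound 2 to compound 3 (0.49 log units; beyond the scatter); further off is compound 1, with a 4.0-fold higher number from compound 1 to compound 3 (0.60 log units; beyond the scatter).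

Compound 4, `C/C(=N\OC(=O)N(C)C)c1ccc(Sc2cc(F)cc(C3CCOCC3)c2)cc1`, is not yet measured. It differs from compound 3 by dimethylcarbamoyl in place of isopropyl on an oxygen.

The step that bears most directly on this change is the one at the same oxygen, a 4.0-fold higher number from compound 1 to compound 3 (0.60 log units; beyond the scatter), where a larger group on that oxygen went with a lower number than the isopropyl of compound 3. The other step, a 3.1-fold higher number from compound 2 to compound 3 (0.49 log units; beyond the scatter), also moves away from compound 3 toward a lower number. Neither involves a dimethylcarbamoyl, so the direction is only loosely indicated. The expectation for compound 4 is therefore a step toward a somewhat lower number, a 1.8-fold lower number from compound 3 to compound 4 (0.26 log units; within the scatter), with wide uncertainty. Compound 4 is estimated at 500 nM, in the range 150 nM to 1600 nM.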

Compound 4, half-maximal inhibitory concentration: 2610 nM
Compound 4: the middle estimate sits 5.2-fold (0.72 log units) below what was measured; the whole stated range lies below it.
By their numbers in this assay, from the lowest: compounds 1 and 2 (each within the scatter of the next); then compound 3; then compound 4.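

In this assay, size alone does not order the groups on this oxygen: a 2.8-fold higher number from compound 3 to compound 4 (0.45 log units; beyond the scatter) comes with dimethylcarbamoyl in place of isopropyl, whereas the larger 2-((5-methyl-1,3,4-thiadiazol-2-yl)sulfanyl)ethyl of compound 1 goes with a lower number than either. The distance from the two lower compounds is now wider, with an 8.7-fold higher number from compound 2 to compound 4 (0.94 log units; beyond the scatter) on the change at the aromatic carbon and an 11-fold higher number from compound 1 to compound 4 (1.05 log units; beyond the scatter) at the oxygen, and compound 4 stands beyond the scatter from all three others as the weakest inhibitor shown. Nothing available accounts for this rise in the number.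

From the compounds shown here alone, it remains open whether the carbonyl or the dimethylamino part of the new group goes with the higher number, which an acetyl group on this oxygen would help separate. A plain ethyl or longer alkyl chain there would test how much of the lower number of compound 1 needs the thiadiazole.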